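Aryl exchange on compound 2: expected reductase inhibition

This account rests on a few compounds, and the source may have more. Where it says the series, first, only, none or still open, it means among the compounds named here.

Two compounds carry numbers in an assay on microsomes from liver for inhibition of 3-hydroxy-3-methylglutaryl-coenzyme A reductase (Rattus norvegicus) (a lower number here means a stronger inhibitor, a higher number a weaker inhibitor), so far. Compound 1 `CC[C@H](C)C(=O)O[C@H]1C[C@@H](C)C=C2C=C[C@H](C)[C@H](CC[C@@H]3C[C@@H](O)CC(=O)O3)[C@]21C` gives 3 nM in this assay. Compound 2 `O=C(O)C[C@H](O)C[C@H](O)CCn1c(C(F)(F)F)nc(-c2ccc(F)cc2)c1-c1ccc(F)cc1` gives 38 nM in this assay, the higher of the two numbers; the gap between compound 1 and compound 2 lies beyond the scatter. Among the compounds with values here, no pair of measured compounds differs in a single place, so no measured step is available to guide the next change.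

Compound 3 `Cc1cc(C)cc(-c2nc(C(F)(F)F)n(CC[C@@H](O)C[C@@H](O)CC(=O)O)c2-c2ccc(F)cc2)c1` is the next candidate. It differs from compound 2 by 3,5-dimethylphenyl in place of 4-fluorophenyl on an aromatic carbon. Nothing measured in this series speaks to such an exchange, and the two aryl groups are matched in size and in counted donors and acceptors, so the step is expected to be small, in either direction, and most likely not beyond the scatter. On that basis compound 3 is estimated at 40 nM in this assay, with a range from 12 nM to 130 nM. The expected step of a 1.1-fold higher number from compound 2 to compound 3 (0.02 log units; within the scatter) is small.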

Compound 3, half-maximal inhibitory concentration: 24 nM
For compound 3 the middle estimate is 1.7-fold (0.22 log units) above the measured one; the measured number falls inside the stated range.
By their numbers in this assay, from the lowest: compound 1; then compounds 3 and 2 (each within the scatter of the next).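

Compound 3 gives the series its first single-place step: on the aromatic carbon two ring bonds from the ring atom that bears a trifluoromethyl group, 3,5-dimethylphenyl in place of 4-fluorophenyl gives a 1.6-fold lower number from compound 2 to compound 3 (0.20 log units; within the scatter) in this assay. At this position, then, the 4-fluorophenyl group and its fluorine are not needed to keep the number of compound 2, and a ring carrying two methyl groups serves equally well. Nothing measured on these compounds accounts for the size of this step.

Still open, from the compounds shown here alone, is how wide the tolerance at this position runs: a pyridine ring, a cyclohexyl group or a phenyl ring carrying a methoxy group would test it. The trifluoromethyl group is also untested, since it stands unchanged in compound 2 and compound 3, and an amide in its place would probe that position.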